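Amide Variations on a Shared Core Give Only Limits

The source may report more compounds than this note shows. Statements on the series, on what has been measured and on what is new or still open speak of the compounds shown alone.

Three compounds have been measured in a functional assay on PC-3 cells (Homo sapiens) for cytotoxicity, read by XTT assay, with a stated time of 72 h; a lower number here means a stronger inhibitor, a higher number a weaker inhibitor:
compound 1 `CCCN(C)C(=O)c1ccc(-c2cc(-c3cc(OC)ccc3OC)no2)s1` gives > 30000 nM.
compound 2 `COc1ccc(OC)c(-c2cc(-c3ccc(C(=O)NCC4CC4)s3)on2)c1` gives > 30000 nM.
compound 3 `COc1ccc(OC)c(-c2cc(-c3ccc(C(=O)N(C)Cc4ccccc4)s3)on2)c1` gives > 30000 nM.

Each of these three values is a limit of the assay rather than a number. All three compounds sit at the limit of > 30000 nM in this assay, at which 3 of the 3 values shown sit, so none of the steps among them can be read: the change from compound 1 to compound 2 is a step that the two limits leave unreadable from compound 1 to compound 2, the change from compound 1 to compound 3 is a step that the two limits leave unreadable from compound 1 to compound 3, and the change from compound 2 to compound 3 is a step that the two limits leave unreadable from compound 2 to compound 3. Compound 3 therefore stands at the limit, alongside the other two, and its amide variation has not moved it into readable territory.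

Compound 4 `COc1ccc(OC)c(-c2cc(-c3ccc(C(=O)NC4CC4)s3)on2)c1` differs from compound 3 in one place: cyclopropylamino in place of benzyl(methyl)amino on a carbonyl carbon. The measured steps that bear on this kind of change, all amide swaps on the same carbonyl carbon, have every one remained at the limit, so no readable step is expected here either, and in neither direction.

The estimate for compound 4 in this assay is 30000 nM, expected to lie between 10000 nM and 100000 nM. The step from compound 3 to compound 4 is thus expected to be a number no higher from compound 3 to compound 4 (the limit leaves the size open), most likely returning only a limit again.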

Compound 4, half-maximal inhibitory concentration: 7800 nM
Beside the measured number, compound 4's estimate is 3.8-fold (0.59 log units) above it, outside the stated range (below it).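

In this assay, a swap on this carbonyl carbon can bring a compound off the limit: cyclopropylamino in place of benzyl(methyl)amino gives an at least 3.8-fold lower number from compound 3 to compound 4 (0.58 log units; beyond the scatter), and cyclopropylamino in place of methyl(propyl)amino gives an at least 3.8-fold lower number from compound 1 to compound 4 (0.58 log units; beyond the scatter). The smallest of the changes is cyclopropyl in place of cyclopropylmethyl on the amide-type nitrogen, which gives an at least 3.8-fold lower number from compound 2 to compound 4 (0.58 log units; beyond the scatter), and since compound 2 also carries the amide hydrogen yet stays at the limit, that hydrogen alone does not go with a readable value in this set. The steps among compound 1, compound 2 and compound 3 still cannot be read, and each new step gives only a smallest possible size, as the three earlier values are limits and not numbers: the limit of > 30000 nM in this assay, at which 3 of the 4 values shown sit.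

Going by these compounds, with a single readable value, it remains open whether the cyclopropyl ring itself matters or whether another small group on the amide nitrogen, such as isopropyl, cyclobutyl or a plain ethyl, would serve as well. On these data alone, all four compounds also share one core, so it is open whether cyclopropylamino would give a comparable step on a different core.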